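Benzoxazolone Amides: From a Thiophene to a Phenyl Amide

The compounds below may be only part of what the source reports. "The series", "measured", "known", "first", "only" and "open" are said of these compounds alone.

Measured compounds:
compound 1, `O=C(Cn1c(=O)oc2cc(Cl)ccc21)Nc1ccccc1`, 20.2%
compound 2, `O=C(Cn1c(=O)oc2cc([N+](=O)[O-])ccc21)Nc1ccccc1`, 26.4%
compound 3, `O=C(Cn1c(=O)oc2ccccc21)NCc1cccs1`, 49.1%

Of the compounds shown here, three share the core of compound 1 and have been tested in an ADME assay on RAW264.7 cells (Mus musculus) for cytotoxicity, read by MTT assay, with a stated time of 72 h, tested at 100 uM; a higher number here means a stronger effect of the compound at the concentration tested, a lower number a weaker effect. Compound 1 gives 20.2%. Compound 2, with nitro in place of chloro on an aromatic carbon, gives 26.4%; the step of a number 6.2 percentage points higher from compound 1 to compound 2 (within the scatter) lies within the scatter. Compound 3 stands highest of the three, with 49.1%, its nearest neighbour being compound 2 and the gap to compound 1 being the widest, both beyond the scatter.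

Compound 4, `O=C(Cn1c(=O)oc2ccccc21)Nc1ccccc1`, has not yet been measured. It differs from compound 3 thus: phenyl in place of (thiophen-2-yl)methyl on an amide-type nitrogen

Among the measured compounds shown here, no measured step covers this change; the only measured step, from compound 1 to compound 2, concerns a substituent on the aromatic ring and was within the scatter. Compounds 1 and 2 both carry phenyl on the amide-type nitrogen and sit well below compound 3, so a decrease is expected in this assay for compound 4. The estimated step is a number 21.1 percentage points lower from compound 3 to compound 4 (beyond the scatter). Compound 4 is thus expected to give about 28%, in the range from 12% to 46%.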

Compound 4, a percentage reported as inhibition, at one concentration (the size of the read-out at that concentration, not a potency): 39.8%
Compound 4: middle estimate off by 11.8 percentage points, on the low side; measured number inside the range.
By their numbers in this assay, from the lowest: compounds 1 and 2 (each within the scatter of the next); then compounds 4 and 3 (each within the scatter of the next).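

In this assay the exchange of (thiophen-2-yl)methyl for phenyl on the amide-type nitrogen gives a number 9.3 percentage points lower from compound 3 to compound 4 (within the scatter), so this assay does not tell the two groups apart at this position, although one carries a five-membered aromatic ring with sulfur and the other a six-membered ring of carbon only. Compound 4 also supplies the parent without a ring substituent that the earlier phenyl amides lacked: hydrogen in place of nitro gives a number 13.4 percentage points higher from compound 2 to compound 4 (beyond the scatter) and hydrogen in place of chloro gives a number 19.6 percentage points higher from compound 1 to compound 4 (beyond the scatter), which places the modest separation of compound 1 and compound 2 from compound 4 on the aromatic carbon rather than on the amide-type nitrogen. Nothing available explains these differences in cytotoxic read-out.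

Because this exchange alters the ring and the chain together, the compounds shown leave open what each contributes, which benzyl or thiophen-2-yl on the same nitrogen would separate. They also leave open whether chloro or nitro on the aromatic carbon would give similar steps with (thiophen-2-yl)methyl on the nitrogen, and how an amine or a carboxylic acid would read there.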